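From pyridin-2-yl to pyridin-4-yl at the assay limit

A few compounds are considered here, and "the series" means these few. Any claim that something is new, unique, unknown or untested is made for them only; others in the source may bear on it.

In a functional assay on cells (Platelet, Homo sapiens) for inhibition (a lower number here means a stronger inhibitor, a higher number a weaker inhibitor), compound 1 `CCOC(=O)c1ccc(-c2nn(Cc3ccccc3Cl)c3ccccc23)cc1` gives > 10000 nM, which is a limit of the assay. Compound 2 `CCOC(=O)c1ccc(-c2nn(Cc3ccccn3)c3ccccc23)cc1` also reaches only a limit, > 10000 nM. Within the data shown here, the one measured step that bears on the change is a step that the two limits leave unreadable from compound 1 to compound 2, and (the limit of > 10000 nM in this assay, at which 2 of the 2 values shown sit). Compound 3 `CCOC(=O)c1ccc(-c2nn(Cc3ccncc3)c3ccccc23)cc1` has the same atoms as compound 2, joined differently: pyridin-4-yl in place of pyridin-2-yl on a saturated chain carbon bound to an aromatic nitrogen. Among the measured compounds shown here, no measured step gives a size or direction for this change, so no shift beyond the scatter is expected, and the estimated step is a number no higher from compound 2 to compound 3 (the limit leaves the size open). Compound 3 is expected at 10000 nM, with an estimated range of 2500 nM to 30000 nM.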

Compound 3, half-maximal inhibitory concentration: > 10000 nM
Compound 3 was reported as a limit; the forecaster's own chance of this, stated with the estimate: 70%; the middle value sits exactly at the limit.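

Compound 3 also reaches only a limit, so no step from compound 1 or compound 2 to compound 3 can be read: the limit of > 10000 nM in this assay, at which 3 of the 3 values shown sit.

The compounds shown leave open whether pyridin-2-yl, pyridin-4-yl or 2-chlorophenyl at this place makes any difference in this assay.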